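The source may hold more compounds than are shown below. What is called first, only, known or untested is meant among the compounds shown, and "the series" means these compounds.

Measured compounds: compound 1 `Cc1ccc(C2CNN=C2S(=O)(=O)CC2=NCCS2)cc1` with 45.1%; compound 2 `O=S(=O)(CC1=NCCO1)C1=NNCC1c1ccccc1` with "not active" (no number reported); compound 3 `O=S(=O)(CC1=NCCS1)C1=NNCC1c1ccc(Cl)cc1` with "not active" (no number reported).

In a functional assay, tested at 100 ug/mL (on this read-out lower numbers stand for a weaker effect and higher numbers for a stronger effect at the one concentration tested), compound 3 stands without a single number, reported only as "not active" (no number reported). One further entry, compound 2, also has no single number in this assay, where compound 2 is given as "not active" (no number reported). Only compound 1 carries a figure, 45.1% in this assay.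

Compound 4 `O=S(=O)(CC1=NCCS1)C1=NNCC1c1ccccc1` is reached from compound 3 by the change (hydrogen in place of chloro on an aromatic carbon), so that 4-chlorophenyl becomes phenyl. Among the measured compounds shown here, no measured step covers this change. Since compound 3 and compound 2 both lack a number, any movement is expected to be small in this assay, with a weak effect the likeliest outcome. Compound 4 is estimated at 15%, within 0% to 40%.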

Compound 4, a percentage reported as activity, at one concentration (the size of the read-out at that concentration, not a potency): "not active" (no number reported)
Nothing numeric was reported for compound 4; the estimate stays without a comparison.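

Compound 4, like compound 3, carries no number in this assay, so no step can be read between them. The compounds shown leave open whether exchanging chloro for hydrogen alters the effect at all. Nothing measured here bears on this result.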